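A few compounds are considered here, and "the series" means these few. Any claim that something is new, unique, unknown or untested is made for them only; others in the source may bear on it.

In a functional assay on UACC-257 cells (Homo sapiens) for inhibition, read by sulforhodamine B assay, with a stated time of 48 h (a lower number here means that less compound is tolerated, a higher number that more compound is tolerated), compound 1 `O=C(Nc1cccc(-n2cc(-c3ccncc3)c(-c3ccc(Cl)c(O)c3)n2)c1)Nc1cccc(C(F)(F)F)c1` is known only as a limit, > 32500 nM. Compound 3 `COc1cc(-c2nn(-c3cccc(NC(=O)Nc4cccc(C(F)(F)F)c4)c3)cc2-c2ccncc2)ccc1Cl` differs from it by methyl in place of hydrogen on an oxygen on an aromatic ring, so that 4-chloro-3-hydroxyphenyl becomes 4-chloro-3-methoxyphenyl. Compound 2 `COc1cc(-c2nn(-c3cccc(NC(=O)c4cccc(C(F)(F)F)c4)c3)cc2-c2ccncc2)ccc1Cl`, which carries the 4-chloro-3-methoxyphenyl group, also gives only a limit, > 50000 nM. On that basis, no change beyond the scatter is expected in this assay. The estimated step is a step that the limit leaves unreadable from compound 1 to compound 3. Compound 3 is expected at 45000 nM, with an estimated range of 20000 nM to 100000 nM.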

Compound 3, concentration lethal to 50% of the cells: 7580 nM
Beside the measured number, compound 3's estimate is 5.9-fold (0.77 log units) above it, and the stated range ends above it.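

In this assay, methoxy in place of hydroxy gives a real drop, an at least 4.2-fold lower number from compound 1 to compound 3 (0.63 log units; beyond the scatter). With the 4-chloro-3-methoxyphenyl group kept, (3-(trifluoromethyl)phenyl)amino in place of 3-(trifluoromethyl)phenyl on the carbonyl carbon also counts, an at least 6.5-fold lower number from compound 2 to compound 3 (0.81 log units; beyond the scatter). Of the compounds shown, only compound 3 carries both features, and only compound 3 gives a number rather than a limit.

Going by these compounds, whether ethoxy or an amine on that aromatic carbon would lower the number further stays open. On these data alone, the full size of both steps also stays open: their starting values are limits.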